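Swapping a Para Halogen for Ethoxy on the Aryl Amide

A few compounds are considered here, and "the series" means these few. Any claim that something is new, unique, unknown or untested is made for them only; others in the source may bear on it.

Of the compounds shown here, three built on one shared core have been measured in an assay on isolated protein for inhibition of Rho-associated protein kinase 2 (Homo sapiens), read by scintillation counting, radiometric assay and 33P incorporation, with a stated time of 40 min, in the presence of a further agent that is not named here; on this read-out lower numbers stand for stronger inhibition and higher numbers for weaker inhibition. Compound 1 `CCCC(=O)Nc1cccc(NC(=O)COc2ccc3c(=O)ccoc3c2)c1` carries a propyl chain on its second amide carbonyl and gives 176 nM. Compound 2 `O=C(COc1ccc2c(=O)ccoc2c1)Nc1cccc(NC(=O)c2ccc(F)cc2)c1` replaces that chain with a 4-fluorophenyl ring and gives 54 nM, a 3.3-fold lower number from compound 1 to compound 2 (0.51 log units; beyond the scatter). Compound 3 `O=C(COc1ccc2c(=O)ccoc2c1)Nc1cccc(NC(=O)c2ccc(Br)cc2)c1` carries a 4-bromophenyl ring instead and gives 49 nM, a 3.6-fold lower number from compound 1 to compound 3 (0.56 log units; beyond the scatter). Compound 3 thus shows the lowest number of the three, but against compound 2 the difference is only a 1.1-fold lower number from compound 2 to compound 3 (0.04 log units; within the scatter), so the two cannot be ranked.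

Compound 4 `CCOc1ccc(C(=O)Nc2cccc(NC(=O)COc3ccc4c(=O)ccoc4c3)c2)cc1` keeps the aryl amide and changes only the group on it: ethoxy in place of bromo on an aromatic carbon. Within the data shown here, no measured step covers this exact swap. The steps from compound 1 show that an aryl ring in place of propyl helps, while the halogen swap from compound 2 to compound 3 stayed within the scatter, giving no sign that the group para to the large carbonyl matters much. Compound 4 is therefore expected to land near compound 3, with a 1.2-fold higher number from compound 3 to compound 4 (0.09 log units; within the scatter) in this assay, estimated at 60 nM with a likely range of 25 nM to 150 nM.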

Compound 4, half-maximal inhibitory concentration: 9 nM
Estimate against measurement, compound 4: 6.7-fold (0.82 log units) above, outside the stated range (below it).
By their numbers in this assay, from the lowest: compound 4; then compounds 3 and 2 (each within the scatter of the next); then compound 1.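

The group para to a large group does matter in this assay after all: ethoxy in place of bromo gives a 5.4-fold lower number from compound 3 to compound 4 (0.74 log units; beyond the scatter) and ethoxy in place of fluoro gives a 6.0-fold lower number from compound 2 to compound 4 (0.78 log units; beyond the scatter) while the two halogens themselves could not be ranked. Going from the propyl chain to the 4-ethoxyphenyl ring gives a 20-fold lower number from compound 1 to compound 4 (1.29 log units; beyond the scatter) and so is a large step where the two halogen-bearing rings gave modest ones, which means the ring alone does not set the size of the gain. Nothing in the data shown explains this gain.

Still open, on these data alone, is whether the gain follows the oxygen of the ethoxy group or the two carbons attached to it, a question that methoxy, propoxy or a plain ethyl group at this place could help settle. An amine or a hydroxyl group at the same place also remains an open case.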